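Trifluoromethoxy for bromo at the far end of toxicity

This account rests on a few compounds, and the source may have more. Where it says the series, first, only, none or still open, it means among the compounds named here.

Compound 3 `Cc1c(Cc2ccc(Br)cc2)c(=O)oc2cc(OCC(O)CN3CCC(C(N)=O)CC3)ccc12` carries a 4-bromobenzyl on the shared core. In an ADME assay on A549 cells (Homo sapiens) for cytotoxicity, read by CellTiter-Glo (on this read-out higher numbers stand for lower toxicity in this test and lower numbers for higher toxicity in this test), compound 3 gives > 100000 nM, which is a limit of the assay and not a number. Within the data shown here, compound 2 `Cc1c(Cc2cccc(F)c2)c(=O)oc2cc(OCC(O)CN3CCC(C(N)=O)CC3)ccc12` is its only single-change neighbour, and in this assay compound 2 gives 53300 nM. Among the measured compounds shown here, the step of an at least 1.8-fold higher number from compound 2 to compound 3 (0.27 log units; that floor lies within the scatter) is the only measured step and rests on that limit (the limit of > 100000 nM in this assay, at which 2 of the 3 values shown sit). Compound 1 `Cc1c(Cc2ccccc2)c(=O)oc2cc(OCC(O)CNc3ccccc3)ccc12` is the remaining measured compound. In this assay compound 1 gives > 100000 nM, which is a limit of the assay and not a number.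

Compound 4 `Cc1c(Cc2ccc(OC(F)(F)F)cc2)c(=O)oc2cc(OCC(O)CN3CCC(C(N)=O)CC3)ccc12` differs from compound 3 by trifluoromethoxy in place of bromo on an aromatic carbon. For the measured compounds named here, no measured step in this assay covers this change, and the only step shown sits at the limit, so no direction can be read from it. Compound 4 is therefore expected to sit near the limit as well, with an expected step that the limit leaves unreadable from compound 3 to compound 4. Compound 4 is estimated at 120000 nM, between 40000 nM and 400000 nM.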

Compound 4, half-maximal cytotoxic concentration: 68200 nM
Estimate against measurement, compound 4: 1.8-fold (0.25 log units) above; measured number inside the range.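

In this assay, trifluoromethoxy in place of bromo on this aromatic carbon gives an at least 1.4-fold lower number from compound 3 to compound 4 (0.16 log units; that floor lies within the scatter), so compound 4 has a measured number where compound 3 has only a limit, though the floor of this step lies within the scatter. The step therefore shows no firm loss or gain and rests on a limit: the limit of > 100000 nM in this assay, at which 2 of the 4 values shown sit. The 4-(trifluoromethoxy)phenyl group set against the 3-fluorophenyl group gives a 1.3-fold higher number from compound 2 to compound 4 (0.11 log units; within the scatter), so the measured numbers of these two compounds cannot be told apart in this test.

From the compounds shown here alone, how far the true value of compound 3 lies from that of compound 4 stays open. Going by these compounds, it also stays open whether an amine or a carboxylic acid on this aromatic carbon would move the number beyond the scatter.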